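This account rests on a few compounds, and the source may have more. Where it says the series, first, only, none or still open, it means among the compounds named here.

Measured so far in a functional assay on A2780 cells (Homo sapiens) for antiproliferative activity, read by MTT assay, with a stated time of 48 h; on this read-out lower numbers stand for stronger inhibition of growth and higher numbers for weaker inhibition of growth:
- Compound 1 `COC(=O)N1N=C(c2ccccc2)CC1c1cc(OC)c(OC)c(OC)c1`: 2770 nM
- Compound 2 `COC(=O)N1N=C(c2cccc(OC)c2)CC1c1cc(OC)c(OC)c(OC)c1`: 2780 nM
- Compound 3 `CCOc1cccc(C2=NN(C(=O)OC)C(c3cc(OC)c(OC)c(OC)c3)C2)c1`: 760 nM

Compound 3 has the lowest number of the three, and its steps to both others lie beyond the scatter. The next compound, compound 4 `COC(=O)N1N=C(c2ccc(O)cc2)CC1c1cc(OC)c(OC)c(OC)c1`, differs from it at one place: 4-hydroxyphenyl in place of 3-ethoxyphenyl on a carbon with a double bond to nitrogen. Thus 4-hydroxyphenyl stands in place of 3-ethoxyphenyl on a carbon with a double bond to nitrogen.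

Among the compounds with values here, three measured steps bear on this change. Ethoxy in place of hydrogen gave a 3.6-fold lower number from compound 1 to compound 3 (0.56 log units; beyond the scatter), and the methyl that extends methoxy to ethoxy gave a 3.7-fold lower number from compound 2 to compound 3 (0.56 log units; beyond the scatter). Both are modest, whereas methoxy in place of hydrogen gave a 1.0-fold higher number from compound 1 to compound 2 (0.00 log units; within the scatter), which is within the scatter. Within the data shown here, no measured compound carries the 4-hydroxyphenyl group, so that half of the change is untested. Compound 4 lacks the ethoxy group, so a modest move to a higher number in this assay is expected, towards compound 1 at 2770 nM. The expected step is a 3.2-fold higher number from compound 3 to compound 4 (0.50 log units; beyond the scatter). For compound 4 the estimate is 2400 nM, with an expected range from 800 nM to 7000 nM.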

Compound 4, concentration for 50% growth inhibition: 2520 nM
Estimate against measurement, compound 4: 1.1-fold (0.02 log units) below, within the range that was stated.
By their numbers in this assay, from the lowest: compound 3; then compounds 4, 1 and 2 (each within the scatter of the next).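

In this assay the change from 3-ethoxyphenyl to 4-hydroxyphenyl on the carbon with a double bond to nitrogen gave a 3.3-fold higher number from compound 3 to compound 4 (0.52 log units; beyond the scatter) and left compound 3 alone with the lowest number. Hydroxy in place of hydrogen gave a 1.1-fold lower number from compound 1 to compound 4 (0.04 log units; within the scatter) and 4-hydroxyphenyl in place of 3-methoxyphenyl gave a 1.1-fold lower number from compound 2 to compound 4 (0.04 log units; within the scatter) so the new group sets compound 4 apart from neither compound 1 nor compound 2, and among these four compounds only the 3-ethoxyphenyl group stands apart at this position. No measurement at hand explains this result.

As far as these compounds go, whether a propoxy chain in place of the ethoxy group would lower the number further remains open. So does the outcome for an amine in place of the hydroxy group of compound 4.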